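Swapping the Amine-Side Group in a Receptor Blocker

A few compounds are considered here, and "the series" means these few. Any claim that something is new, unique, unknown or untested is made for them only; others in the source may bear on it.

Among the compounds with values here, compound 2 `NCc1cccc(CN(C[C@H]2Cc3ccccc3CN2)[C@H]2CCCc3cccnc32)c1` is the weaker of the two compounds measured so far. In a functional assay on cells for antagonist activity at C-X-C chemokine receptor type 4 (Homo sapiens), read by fluorescence and calcium flux, with stated times of 25 min and 90 s (a higher number here means a weaker inhibitor, a lower number a stronger inhibitor), compound 2 gives 292 nM, while compound 1 `c1ccc2c(c1)CN[C@@H](CN(CCCCNCC1CCSCC1)[C@H]1CCCc3cccnc31)C2` gives 69.6 nM. Within the data shown here, the one step known, a 4.2-fold higher number from compound 1 to compound 2 (0.62 log units; beyond the scatter), exchanged a group of 11 heavy atoms with a six-membered non-aromatic ring for a smaller group of 8 heavy atoms at the saturated chain carbon bound to an amine nitrogen. Compound 3 `C(=C/CN(C[C@H]1Cc2ccccc2CN1)[C@H]1CCCc2cccnc21)\CNCc1cccnc1` reverses the direction of that size change at the same place: a group of 11 heavy atoms (9 carbon, 2 nitrogen; one six-membered aromatic ring with 1 hetero atom) in place of a group of 8 heavy atoms (7 carbon, 1 nitrogen; one six-membered aromatic ring of carbon only), on a saturated chain carbon bound to an amine nitrogen. Since the earlier step at this position weakened inhibition when the group shrank, the return to a group of 11 heavy atoms is expected to strengthen it somewhat, though the entering group carries a pyridine-type ring and a double bond rather than the ring of compound 1, so the expected step is only a 1.9-fold lower number from compound 2 to compound 3 (0.29 log units; within the scatter). For compound 3 the estimate in this assay is 150 nM, ranging from 50 nM to 450 nM.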

Compound 3, half-maximal inhibitory concentration: 92.8 nM
Compound 3: middle estimate off by 1.6-fold (0.21 log units), on the high side; the measured number falls inside the stated range.
By their numbers in this assay, from the lowest: compounds 1 and 3 (each within the scatter of the next); then compound 2.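

In this assay, within the data shown here, the change of group gives a 3.1-fold lower number from compound 2 to compound 3 (0.50 log units; beyond the scatter), the first step at this place, on a saturated chain carbon bound to an amine nitrogen, that points towards stronger inhibition. The step of a 1.3-fold higher number from compound 1 to compound 3 (0.12 log units; within the scatter) shows that two unlike groups with the same count of 11 heavy atoms, one with a six-membered aromatic ring with 1 hetero atom and a double bond, the other with a non-aromatic ring holding sulfur, cannot be told apart here. Among these compounds, the smaller 3-(aminomethyl)phenyl group therefore gives the highest number, and no compound goes against this.

Group size cannot yet be separated from the other differences between these groups, and a group of another kind, such as a carboxylic acid, would test how broad this tolerance is. No measurement shown explains these steps.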